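Thiosemicarbazones: swapping an ortho chloro for nitro

A few compounds are considered here, and "the series" means these few. Any claim that something is new, unique, unknown or untested is made for them only; others in the source may bear on it.

Measured compounds and their growth-inhibition values:
- compound 1 `CC1=CC[C@H](C(C)(C)NC(=S)N/N=C/c2ccccc2)CC1`: 13000 nM
- compound 2 `CC1=CC[C@H](C(C)(C)NC(=S)N/N=C/c2ccccc2O)CC1`: 1900 nM
- compound 3 `CC1=CC[C@H](C(C)(C)NC(=S)N/N=C/c2ccccc2Cl)CC1`: 64500 nM

In a functional assay on NCI-H460 cells (Homo sapiens) for inhibition, read by sulforhodamine B assay, with a stated time of 48 h (on this read-out lower numbers stand for stronger inhibition of growth and higher numbers for weaker inhibition of growth), compound 3 gives the highest number of the three, so it is the weakest of this set. Its nearest neighbour is compound 1, as shown by the step of a 5.0-fold higher number from compound 1 to compound 3 (0.70 log units; beyond the scatter), and the furthest is compound 2, as shown by a 34-fold higher number from compound 2 to compound 3 (1.53 log units; beyond the scatter). The step of a 6.8-fold lower number from compound 1 to compound 2 (0.84 log units; beyond the scatter) shows that a hydroxy in this position helps.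

Compound 4 `CC1=CC[C@H](C(C)(C)NC(=S)N/N=C/c2ccccc2[N+](=O)[O-])CC1` differs from compound 3 by nitro in place of chloro on an aromatic carbon. Among the measured compounds shown here, no measured step involves a nitro group, so the only guidance is that this position on the ring matters: hydroxy improved, chloro worsened, each by a modest to large amount. A nitro, like chloro, has no hydrogen-bond donor, but it does bring acceptors. The expectation is therefore a step of a 2.2-fold lower number from compound 3 to compound 4 (0.33 log units; beyond the scatter) of uncertain direction and modest size. Compound 4 is expected to give about 30000 nM, in the range 8000 nM to 120000 nM.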

Compound 4, concentration for 50% growth inhibition: 5000 nM
Compound 4: middle estimate off by 6.0-fold (0.78 log units), on the high side; measured number outside the range, below it.
By their numbers in this assay, from the lowest: compound 2; then compound 4; then compound 1; then compound 3.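

In this assay the swap matters far more than its shared lack of a hydrogen-bond donor might suggest, with a 13-fold lower number from compound 3 to compound 4 (1.11 log units; beyond the scatter) at the same ring position, so chloro and nitro are clearly not interchangeable here. Nitro also improves on plain hydrogen, with a 2.6-fold lower number from compound 1 to compound 4 (0.41 log units; beyond the scatter) as the step, while chloro worsened it, so a group with no hydrogen-bond donor can still lower the number at this position. Hydroxy nevertheless remains ahead of nitro, as a 2.6-fold higher number from compound 2 to compound 4 (0.42 log units; beyond the scatter) shows, which keeps compound 2 the strongest of the four.

The data shown offer no measurement that explains why these groups differ. Going by these compounds, how an amine or a methoxy group would rank at this position, and whether nitro would give the same gain elsewhere on the ring, remains open.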